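Swapping trifluoromethyl for methoxy on the aryl ring

The source may report more compounds than this note shows. Statements on the series, on what has been measured and on what is new or still open speak of the compounds shown alone.

Measured so far:
compound 1 `COc1ccc(-c2nc(C(=O)/C=C\Nc3ccc4[nH]ccc4c3)c3ccccn23)cc1`: 4800 nM
compound 2 `COc1ccc(-c2nc(C(=O)/C=C\Nc3ccc(Cl)cc3)c3ccccn23)cc1`: "not determined" (no result reported)
compound 3 `O=C(/C=C\Nc1ccc(F)cc1)c1nc(-c2ccc(C(F)(F)F)cc2)n2ccccc12`: > 30000 nM

All three share one core, differing in the two aryl rings at its ends. In a functional assay on A549 cells (Homo sapiens) for cytotoxicity, read by MTT assay, with a stated time of 48 h (on this read-out higher numbers stand for weaker inhibition and lower numbers for stronger inhibition), compound 1 gives 4800 nM. Compound 2 is recorded only as "not determined" (no result reported). For compound 3 the result is a limit, not a number: compound 3 shows > 30000 nM, which means it sits at the limit of > 30000 nM in this assay, at which 1 of the 3 values shown sits. Compound 4 `COc1ccc(-c2nc(C(=O)/C=C\Nc3ccc(F)cc3)c3ccccn23)cc1`, not yet measured, differs from compound 3 in one place: methoxy in place of trifluoromethyl on an aromatic carbon. Going by the values given here, no measured pair isolates this change, so its effect is open. Since compound 1, also carrying methoxy, reaches 4800 nM, a gain is expected, about an at least 2.0-fold lower number from compound 3 to compound 4 (0.30 log units; that floor lies within the scatter). Compound 4 is therefore estimated at 15000 nM, somewhere between 4000 nM and 60000 nM.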

Compound 4, half-maximal inhibitory concentration: > 30000 nM
Compound 4: no number, only a limit; the forecaster's own chance of this, stated with the estimate: 40%; middle value at least 2.0-fold (0.30 log units) away from the limit.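

Compound 3 and compound 4 are both limits in this assay, so the step between them cannot be read, and no effect of methoxy over trifluoromethyl can be seen here. Both compounds share one limit: the limit of > 30000 nM in this assay, at which 2 of the 4 values shown sit. With methoxy kept, the other end does give a readable change, as 4-fluorophenyl in place of 1H-indol-5-yl on the amine nitrogen goes with an at least 6.2-fold higher number from compound 1 to compound 4 (0.79 log units; beyond the scatter). On these data alone, whether trifluoromethyl would change the result with 1H-indol-5-yl at that end remains open. So does the effect of an amine or a carboxylic acid in place of methoxy.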